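The source may report more compounds than this note shows. Statements on the series, on what has been measured and on what is new or still open speak of the compounds shown alone.

Working notes on the series in an ADME assay on Karpas-1106P cells (Homo sapiens) for cytotoxicity; on this read-out lower numbers stand for an effect already at smaller amounts and higher numbers for an effect only at larger amounts of compound.

Compound 1 `Cc1ccc(S(=O)(=O)N[C@@H](CC(=O)NC(C)(C)C)C(=O)NCCNC(=O)Nc2ccccc2)cc1` gives > 11100 nM, a limit of this assay rather than a number.
Compound 2 `Cc1ccc(S(=O)(=O)N[C@@H](CC(=O)NC(C)(C)C)C(=O)NCCNC(=O)c2cc(Cl)ccn2)cc1` gives > 11100 nM, again a limit.
Compound 3 `Cc1ccc(S(=O)(=O)N[C@@H](CC(=O)NC(C)(C)C)C(=O)NCCNC(=O)c2ccc(F)c(F)c2)cc1` gives > 11100 nM, also a limit.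

Compound 3 therefore stands where every measured member of the series stands: at the assay limit, as summarised by the limit of > 11100 nM in this assay, at which 3 of the 3 values shown sit. For the measured compounds named here, no compound in the set has yielded a finite number, so none can be ranked against another.

Compound 4 `Cc1ccc(S(=O)(=O)N[C@@H](CC(=O)NC(C)(C)C)C(=O)NCCNC(=O)c2cccc(C(F)(F)F)c2)cc1` differs from compound 3 in one place: 3-(trifluoromethyl)phenyl in place of 3,4-difluorophenyl on a carbonyl carbon. The measured steps that touch the same carbonyl carbon are a step that the two limits leave unreadable from compound 1 to compound 2, a step that the two limits leave unreadable from compound 1 to compound 3 and a step that the two limits leave unreadable from compound 2 to compound 3; each is left unreadable in size and direction by the two limits. Three changes of the aryl group on that carbonyl carbon have thus not moved any compound off the limit, and the change to compound 4 is of the same kind. The step that the limit leaves unreadable from compound 3 to compound 4 is expected to be none beyond the scatter, with compound 4 most likely reported as a limit as well. Compound 4 is estimated at 20000 nM in this assay, within a range of 11100 nM to 60000 nM.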

Compound 4, half-maximal effective concentration: > 11100 nM
Compound 4: only a limit was reported; the forecaster's own chance of this, stated with the estimate: 85%; the middle value is on the limit's open side.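

In this assay compound 4 gives > 11100 nM, a limit and not a number. Its steps to compound 1, compound 2 and compound 3 cannot be read: the limit of > 11100 nM in this assay, at which 4 of the 4 values shown sit.

The compounds shown leave open whether any group on that carbonyl carbon yields a finite value.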